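Third methoxy on the aryl of compound 2: notes

The source may report more compounds than this note shows. Statements on the series, on what has been measured and on what is new or still open speak of the compounds shown alone.

Measured so far:
compound 1, `Cc1cc(O)c(C2=NN(c3ccc(S(N)(=O)=O)cc3)C(/C=C/c3ccccc3)C2)cc1Cl`, in a functional assay on SK-MEL-2 cells (Homo sapiens) for antiproliferative activity, with a stated time of 48 h (a higher number here means a weaker inhibitor of growth, a lower number a stronger inhibitor of growth), gives 16800 nM
compound 2, `COc1ccc(C2CC(c3cc(Cl)c(C)cc3O)=NN2c2ccc(S(N)(=O)=O)cc2)cc1OC`, in this assay gives 5870 nM

Among the measured compounds shown here, compound 2 holds the lower of the two numbers; the only other value, that of compound 1, sits higher by a 2.9-fold lower number from compound 1 to compound 2 (0.46 log units; beyond the scatter), a change that swaps the 2-phenylethenyl group on the saturated ring carbon for a 3,4-dimethoxyphenyl group.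

Compound 3, `COc1ccc(C2CC(c3cc(Cl)c(C)cc3O)=NN2c2ccc(S(N)(=O)=O)cc2)c(OC)c1OC`, differs from compound 2 in one place: methoxy in place of hydrogen on an aromatic carbon. For the measured compounds named here, no measured step concerns a methoxy added to an aromatic carbon, and the single step in hand, a 2.9-fold lower number from compound 1 to compound 2 (0.46 log units; beyond the scatter), changes a different part of the molecule, so it gives no direct guide to the size or direction of this change. The expectation is therefore a step within the usual scatter, a 1.2-fold lower number from compound 2 to compound 3 (0.07 log units; within the scatter), in this assay. Compound 3 is expected to give about 5000 nM, with a range from 1800 nM to 14000 nM.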

Compound 3, concentration for 50% growth inhibition: 3530 nM
Estimate against measurement, compound 3: 1.4-fold (0.15 log units) above; the range from low to high includes it.
By their numbers in this assay, from the lowest: compounds 3 and 2 (each within the scatter of the next); then compound 1.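

In this assay, methoxy in place of hydrogen on an aromatic carbon, ortho to a large group and ortho to a methoxy group, gives a step within the scatter (a 1.7-fold lower number from compound 2 to compound 3 (0.22 log units; within the scatter)), so this carbon accepts the added methoxy with no measurable change in growth inhibition. The 2,3,4-trimethoxyphenyl group in place of 2-phenylethenyl on the saturated ring carbon gives a modest step beyond the scatter (a 4.8-fold lower number from compound 1 to compound 3 (0.68 log units; beyond the scatter)), in the same direction as the step already seen with 3,4-dimethoxyphenyl. No measurement in hand offers an explanation for either step.

Going by these compounds, whether this aromatic carbon would tolerate an amine or an ethoxy group in place of methoxy remains open. Also open, on these data alone, is whether a methoxy here would behave the same way without the two neighbouring methoxy groups of compound 3.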